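A few compounds are considered here, and "the series" means these few. Any claim that something is new, unique, unknown or untested is made for them only; others in the source may bear on it.

Working notes on the urea series.

Of the compounds shown here, three sharing one core have been measured in an ADME assay on HEK293 cells (Homo sapiens) for cytotoxicity, with a stated time of 72 h; a lower number here means that less compound is needed, a higher number that more compound is needed for the effect. Compound 1, `COC(=O)c1ccc(NC(=O)Nc2cc(C)nc3ccccc23)cc1`, gives 15000 nM. Compound 2, `Cc1cc(NC(=O)Nc2ccc(C(F)(F)F)cc2)c2ccccc2n1`, gives 25000 nM. Compound 3, `COC(=O)c1cccc(NC(=O)Nc2cc(C)nc3ccccc23)c1`, gives 26000 nM. All three numbers lie within the scatter of one another, so no order among them is claimed.

One change has been measured directly: trifluoromethyl in place of methoxycarbonyl on an aromatic carbon. It made a 1.7-fold higher number from compound 1 to compound 2 (0.22 log units; within the scatter), a step that stays inside the scatter. Compounds 1 and 3 have the same atoms joined differently; the difference between the two cores is not broken down here.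

Compound 4, `Cc1cc(NC(=O)Nc2cccc(C(F)(F)F)c2)c2ccccc2n1`, is not yet measured. It follows from compound 3 by trifluoromethyl in place of methoxycarbonyl on an aromatic carbon. This is the same kind of change as that from compound 1 to compound 2, not the same change: in the measured pair the group sits para to a large group, in the new pair it sits meta to a large group.

The expected step from compound 3 to compound 4 in this assay is a 1.5-fold higher number from compound 3 to compound 4 (0.16 log units; within the scatter), set beside the measured one and resting on compound 1 to compound 2 having made a 1.7-fold higher number from compound 1 to compound 2 (0.22 log units; within the scatter). Among the measured compounds shown here, only one measured pair supports this, and the place differs, so the range is kept wide. Compound 4 is estimated at 38000 nM, expected between 15000 nM and 90000 nM.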

Compound 4, half-maximal effective concentration: 16000 nM
For compound 4 the middle estimate is 2.4-fold (0.38 log units) above the measured one; measured number inside the range.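

In this assay, trifluoromethyl in place of methoxycarbonyl, meta to a large group, makes a 1.6-fold lower number from compound 3 to compound 4 (0.21 log units; within the scatter). Set beside the earlier step, the same change does not carry over as one fixed step from one core to the other, since the two steps run in opposite directions and the gap between them is larger than the scatter allows: the same change on two cores in this assay, a 1.7-fold higher number (0.22 log units; within the scatter) from compound 1 to compound 2 and a 1.6-fold lower number (0.21 log units; within the scatter) from compound 3 to compound 4, 2.7-fold (0.43 log units) apart, beyond the scatter of two such steps. Among the compounds shown here, each step taken alone still stays inside the scatter, and with only one pair on each core the series does not show what separates the two steps, whether the gap would hold up on repeated measurement, or how the change would behave on any further core.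

The compounds shown carry only methoxycarbonyl or trifluoromethyl at the place that varies, so it remains open how a carboxylic acid, an amine or a nitrile at that place would read on either core. Going by these compounds, it also remains open whether replacing the methyl group on the shared part of the series, or the urea link itself, would shift the numbers in this assay beyond the scatter.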